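Swapping the sulfonyl substituent in a nicotinamide phosphoribosyltransferase series

The source may report more compounds than this note shows. Statements on the series, on what has been measured and on what is new or still open speak of the compounds shown alone.

Measured compounds:
Compound 1, `CC(C)n1cc(S(=O)(=O)c2ccc(CNC(=O)N3Cc4ccncc4C3)cc2)cn1`: 20 nM
Compound 2, `O=C(NCc1ccc(S(=O)(=O)C2CCOCC2)cc1)N1Cc2ccncc2C1`: 26 nM
Compound 3, `O=C(NCc1ccc(S(=O)(=O)C2CCN(C3COC3)CC2)cc1)N1Cc2ccncc2C1`: 31 nM

The three measured compounds share one core and differ only in the group on the sulfonyl sulfur. In an assay on isolated protein for inhibition of Nicotinamide phosphoribosyltransferase (Homo sapiens), read by mass spectrometry, with stated times of 15 min and 30 min (a lower number here means a stronger inhibitor, a higher number a weaker inhibitor), compound 3 gives 31 nM, the highest of the three numbers, but its distance to the other two is small: the step of a 1.2-fold higher number from compound 2 to compound 3 (0.08 log units; within the scatter) and the step of a 1.6-fold higher number from compound 1 to compound 3 (0.19 log units; within the scatter) both lie within the scatter, so compound 3 cannot be called weaker than compound 1 or compound 2.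

Compound 4, `O=C(NCc1ccc(S(=O)(=O)N2CCC[C@H](O)C2)cc1)N1Cc2ccncc2C1`, continues the same exchange: 3-hydroxypiperidin-1-yl in place of 1-(oxetan-3-yl)piperidin-4-yl on a sulfonyl sulfur. For the measured compounds named here, the entering group brings a hydrogen-bond donor and joins the sulfonyl sulfur through a ring nitrogen rather than a ring carbon, which none of the measured steps has tested.

Going by the values given here, the steps that bear on this change are a 1.3-fold higher number from compound 1 to compound 2 (0.11 log units; within the scatter), a 1.6-fold higher number from compound 1 to compound 3 (0.19 log units; within the scatter) and a 1.2-fold higher number from compound 2 to compound 3 (0.08 log units; within the scatter); all three are within the scatter. This assay has so far tolerated every change at the sulfonyl sulfur without a clear shift, so compound 4 is expected to land close to compound 3, with a modest widening of the range for the untested ring nitrogen, the estimated step being a 1.3-fold higher number from compound 3 to compound 4 (0.11 log units; within the scatter). Compound 4 is estimated at 40 nM, with a range from 15 nM to 120 nM.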

Compound 4, half-maximal inhibitory concentration: 770 nM
For compound 4 the middle estimate is 19-fold (1.28 log units) below the measured one; measured number above the stated range.
By their numbers in this assay, from the lowest: compounds 1, 2 and 3 (each within the scatter of the next); then compound 4.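

In this assay, for the compounds shown here, the group on the sulfonyl sulfur turns out to matter far more than the earlier compounds suggested: 3-hydroxypiperidin-1-yl gives a 25-fold higher number from compound 3 to compound 4 (1.40 log units; beyond the scatter) and the comparisons with the other two groups agree, with a 30-fold higher number from compound 2 to compound 4 (1.47 log units; beyond the scatter) and a 39-fold higher number from compound 1 to compound 4 (1.59 log units; beyond the scatter) as the remaining steps. Compound 1, compound 2 and compound 3 all join their group to the sulfonyl sulfur through a ring carbon and sit within the scatter of one another, so their agreement says nothing about compound 4, the only one of the four joined through a ring nitrogen and the only one with a hydrogen-bond donor in this group. Nothing shown here explains why this exchange weakens inhibition so sharply.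

The compounds shown leave open whether the ring nitrogen, the hydroxyl or both account for the step, as compound 4 brings them in together. Plain piperidin-1-yl, with no hydroxyl, and 4-hydroxycyclohexyl, with the hydroxyl kept but the link through carbon, would pull those two changes apart.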